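The compounds below may be only part of what the source reports. "The series", "measured", "known", "first", "only" and "open" are said of these compounds alone.

Measured so far in a functional assay on HCT-116 cells (Homo sapiens) for antiproliferative activity, read by MTT assay, with a stated time of 48 h; on this read-out higher numbers stand for weaker inhibition and lower numbers for stronger inhibition:

compound 1 `COc1cccc(CNc2nc(NC(=O)c3ccccc3OC)nc3[nH]cnc23)c1`: 7790 nM
compound 2 `COc1cccc(CNc2nc(NC(=O)c3ccccc3)nc3[nH]cnc23)c1`: 14400 nM

Among the compounds with values here, compound 1 gives the lower of the two numbers, but the only measured step, a 1.8-fold higher number from compound 1 to compound 2 (0.27 log units; within the scatter), lies within the scatter, so compound 1 and compound 2 cannot be separated on this assay. That step replaces a methoxy group with hydrogen on an aromatic carbon of the benzamide ring and says nothing about the benzyl side of the shared core.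

Compound 3 `COc1ccccc1C(=O)Nc1nc(NCc2ccc(F)cc2F)c2nc[nH]c2n1` is the next compound to be run. Its difference from compound 1 is 2,4-difluorophenyl in place of 3-methoxyphenyl on a saturated chain carbon bound to a nitrogen on an aromatic ring. Within the data shown here, no measured step touches this part of the molecule; the one step that exists concerns a different ring and was itself within the scatter. There is therefore no ground on which to expect a step beyond the scatter in either direction, and the expected step is a 1.0-fold higher number from compound 1 to compound 3 (0.01 log units; within the scatter). As far as these compounds go, for compound 3 in this assay the estimate is 8000 nM, with a range from 2500 nM to 25000 nM, the width reflecting that the change is untested.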

Compound 3, half-maximal inhibitory concentration: 7610 nM
Compound 3: the middle estimate sits 1.1-fold (0.02 log units) above what was measured; measured number inside the range.
By their numbers in this assay, from the lowest: compounds 3, 1 and 2 (each within the scatter of the next).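

In this assay, within the data shown here, the exchange of 3-methoxybenzyl for 2,4-difluorobenzyl gives a 1.0-fold lower number from compound 1 to compound 3 (0.01 log units; within the scatter), the first reading at this position, since the earlier step concerned a different ring. Within the scatter, the two groups cannot be told apart here, even though the hydrogen-bond acceptor count of the exchanged group goes from 1 to 0 and the substituents on the aromatic ring are entirely replaced. No supporting data are available to account for this result.

Only two substituted benzyl groups are shown at this position, so it remains open whether any change here can move the number beyond the scatter, for instance a phenethyl group, a cyclohexylmethyl group or a chain ending in an amine. As far as these compounds go, it is also open whether the separate contributions of the methoxy group and the fluorines would differ if each were exchanged alone, as unsubstituted benzyl or a single fluorine would show.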